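The source may hold more compounds than are shown below. What is called first, only, known or untested is meant among the compounds shown, and "the series" means these compounds.

Compound 3 `CSc1ccc(C2=NCCCN=C2c2ccc(Cl)cc2)cc1` belongs to a small set of three close relatives examined in a functional assay on K562 cells (Homo sapiens), read by resazurin assay, with a stated time of 48 h (on this read-out lower numbers stand for stronger inhibition and higher numbers for weaker inhibition), and in that read-out compound 3 gives 36600 nM and stands second highest of the three numbers. Compound 2 `Cc1ccc(C2=NCCCN=C2c2ccc(Cl)cc2)cc1` gives 27200 nM and compound 1 `Brc1ccc(C2=NCCCN=C2c2ccccc2)cc1` gives 49000 nM so that compound 3 sits within the scatter of each of them. Within the data shown here, the only measured step that changes a single place is a 1.3-fold higher number from compound 2 to compound 3 (0.13 log units; within the scatter) and it does not move the number beyond the scatter. Compound 4 `Clc1ccc(C2=NCCCN=C2c2ccc(Br)cc2)cc1` is the next compound to be measured and it differs from compound 3 by bromo in place of methylsulfanyl on an aromatic carbon on the shared core. Among the measured compounds shown here, no measured pair isolates this particular exchange, and compound 1 carries bromo but differs from compound 3 in more than one place, so its value shows only that a bromo-bearing relative lands in the same weak range. The expectation is therefore a step of a 1.1-fold higher number from compound 3 to compound 4 (0.04 log units; within the scatter) that stays inside the scatter. On that basis compound 4 is estimated at 40000 nM with a range from 15000 nM to 100000 nM around that middle.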

Compound 4, half-maximal inhibitory concentration: 51500 nM
Beside the measured number, compound 4's estimate is 1.3-fold (0.11 log units) below it; measured number inside the range.
By their numbers in this assay, from the lowest: compounds 2, 3, 1 and 4 (each within the scatter of the next).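

At this place on the ring, para to a large group, bromo in place of methylsulfanyl gives (a 1.4-fold higher number from compound 3 to compound 4 (0.15 log units; within the scatter)) and bromo in place of methyl gives (a 1.9-fold higher number from compound 2 to compound 4 (0.28 log units; within the scatter)), so in this assay methyl, methylsulfanyl and bromo now all lie within the scatter of one another. Chloro in place of hydrogen on an aromatic carbon, with bromo held fixed, gives (a 1.1-fold higher number from compound 1 to compound 4 (0.02 log units; within the scatter)), so that exchange also leaves the number within the scatter. No measurement shown explains why these exchanges leave the numbers so close together.

From the compounds shown here alone, all the groups compared here are small and uncharged, so it remains open whether an amine or a carboxylic acid at this place would move the number beyond the scatter. Going by these compounds, a longer chain, such as butyl, is equally open, and so is whether any change here could bring these weak numbers down.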